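A few compounds are considered here, and "the series" means these few. Any claim that something is new, unique, unknown or untested is made for them only; others in the source may bear on it.

Of the compounds shown here, three with a shared core have been measured so far. In an ADME assay for cytotoxicity, read by propidium iodide staining (on this read-out higher numbers stand for lower toxicity in this test and lower numbers for higher toxicity in this test), compound 1 (`Cn1nc(Cc2cccc3ccccc23)c2ccccc2c1=O`) gives 62900 nM, compound 2 (`Cn1nc(Cc2ccc3ccccc3c2)c2ccccc2c1=O`) gives 57200 nM and compound 3 (`CC(C)(C)n1nc(Cc2ccc(Cl)cc2)c2ccccc2c1=O`) gives 72100 nM. These three numbers lie within the usual scatter of one another, so compound 3 stands level with the other two and cannot be told apart from them. For the measured compounds named here, no two of the three differ in only one place, which means that no clean measured step is available as a guide.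

The next structure is compound 4 (`O=c1c2ccccc2c(Cc2ccc(Cl)cc2)nn1-c1ccc([N+](=O)[O-])cc1`), which keeps the rest of compound 3 and puts 4-nitrophenyl in place of tert-butyl on an aromatic nitrogen. Going by the values given here, this is a sizeable change in one place, and none of the measured compounds carries a 4-nitrophenyl group.

The expectation therefore leans on the close agreement between compound 1 at 62900 nM and compound 3 at 72100 nM, two structures that differ in more than one place. The expected step, a 1.8-fold lower number from compound 3 to compound 4 (0.26 log units; within the scatter), stays within the scatter, with a cautious lean toward lower numbers that is a judgement and not a measured trend. For compound 4 the estimated value in this assay is 40000 nM, with an expected range from 15000 nM to 90000 nM.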

Compound 4, half-maximal cytotoxic concentration: 96300 nM
Estimate against measurement, compound 4: 2.4-fold (0.38 log units) below, and the stated range ends below it.
By their numbers in this assay, from the lowest: compounds 2, 1, 3 and 4 (each within the scatter of the next).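

For the compounds shown here, replacing tert-butyl with 4-nitrophenyl on the aromatic nitrogen gives the first clean comparison of a change in one place in this assay (a 1.3-fold higher number from compound 3 to compound 4 (0.13 log units; within the scatter)). This single pair shows that, with the rest of compound 3 kept, this position can carry a much larger group, one that adds a six-membered aromatic ring and 2 hydrogen-bond acceptors, without the read-out moving beyond the usual scatter of repeated measurements. No measured information is available to explain this result.

The compounds shown leave open which part of the new group matters, since a plain phenyl group and a phenyl group carrying an amine or a carboxylic acid in place of the nitro group are not among them, so the ring and the nitro group cannot be judged separately. They also leave open whether the same exchange would give a similarly small step on a compound with a different group on the shared core, such as the naphthalene-bearing structures of compound 1 and compound 2, which carry methyl on that nitrogen.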